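A few compounds are considered here, and "the series" means these few. Any claim that something is new, unique, unknown or untested is made for them only; others in the source may bear on it.

Compound 1 `CS(=O)(=O)c1ccc(C(=O)NCCC(=O)N2CCc3ccccc32)cc1[N+](=O)[O-]` was tested in an assay on isolated protein for inhibition of vitamin D3 receptor (Homo sapiens), read by fluorescence polarization (on this read-out lower numbers stand for stronger inhibition and higher numbers for weaker inhibition), and gave only a limit of the assay: in this assay compound 1 reads > 60000 nM. Compound 2 `Cc1ccc(N2CCN(C(=O)CCCNC(=O)c3ccc(S(C)(=O)=O)c([N+](=O)[O-])c3)CC2)cc1` also reached only a limit, with compound 2 giving > 60000 nM. Compound 1 therefore stands at the limit of > 60000 nM in this assay, at which 2 of the 2 values shown sit, and no measured number separates it from any other compound here. Compound 3 `CC(C)N(C(=O)CCNC(=O)c1ccc(S(C)(=O)=O)c([N+](=O)[O-])c1)C(C)C` has not yet been measured; it differs from compound 1 by diisopropylamino in place of 2,3-dihydro-1H-indol-1-yl on a carbonyl carbon. Within the data shown here, no step between measured compounds is available to guide the expectation, and the two values shown agree only in being limits. Compound 3 is expected to remain at the limit as well, estimated near 60000 nM with a range from 20000 nM to 150000 nM. The expected step is a number no higher from compound 1 to compound 3 (the limit leaves the size open), which is none beyond the scatter.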

Compound 3, half-maximal inhibitory concentration: > 60000 nM
Compound 3 gave a limit, no number; the forecaster's own chance of this, stated with the estimate: 85%; the middle value sits exactly at the limit.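

In this assay compound 3 gives > 60000 nM, which is a limit and not a number. Compound 1 also gave only a limit, so no step can be read between compound 1 and compound 3. The compounds shown leave open whether any change to the shared core would give a measured number, as all of them rest at one limit: the limit of > 60000 nM in this assay, at which 3 of the 3 values shown sit.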